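A few compounds are considered here, and "the series" means these few. Any claim that something is new, unique, unknown or untested is made for them only; others in the source may bear on it.

Three compounds sharing one core have been measured in a functional assay on HeLa cells (Homo sapiens) for inhibition, read by CCK-8 assay, with a stated time of 48 h; on this read-out higher numbers stand for weaker inhibition and lower numbers for stronger inhibition:

compound 1 `COc1cc(-c2ccnc3cc(-c4cn(CO)c5ccccc45)nn23)cc(OC)c1OC`: 103 nM
compound 2 `COc1cc(-c2ccnc3cc(-c4c[nH]c5ccccc45)nn23)cc(OC)c1OC`: 195 nM
compound 3 `COc1cc(-c2ccnc3cc(-c4cn(C)c5ccccc45)nn23)cc(OC)c1OC`: 399 nM

Compound 4 `COc1cc(-c2ccnc3cc(-c4cn(C(=O)OC(C)(C)C)c5ccccc45)nn23)cc(OC)c1OC` has not been measured yet.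

Compound 3 has the highest number of the three, which makes it the weakest inhibitor in this small set. Compound 4 keeps the shared core and differs from compound 3 at one place, with tert-butoxycarbonyl in place of methyl on an aromatic nitrogen.

The measured steps all concern this same nitrogen. Putting hydrogen in place of hydroxymethyl gave a 1.9-fold higher number from compound 1 to compound 2 (0.28 log units; within the scatter), and putting methyl in place of hydrogen gave a 2.0-fold higher number from compound 2 to compound 3 (0.31 log units; beyond the scatter). The widest gap among these compounds is a 3.9-fold higher number from compound 1 to compound 3 (0.59 log units; beyond the scatter). These steps are all small, but none of them brings in tert-butoxycarbonyl, so they are only a loose guide and give no firm direction. The expectation is therefore for no step beyond the scatter, with real room on either side. The estimated change is a 1.1-fold higher number from compound 3 to compound 4 (0.05 log units; within the scatter). For compound 4 the expected value is 450 nM, with an estimated range from 130 nM to 1600 nM.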

Compound 4, half-maximal inhibitory concentration: 3770 nM
Compound 4: the middle estimate sits 8.4-fold (0.92 log units) below what was measured; the whole stated range lies below it.
By their numbers in this assay, from the lowest: compounds 1 and 2 (each within the scatter of the next); then compound 3; then compound 4.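

In this assay, among the compounds shown here, hydrogen, methyl and hydroxymethyl on this aromatic nitrogen span a gap of only a 3.9-fold higher number from compound 1 to compound 3 (0.59 log units; beyond the scatter), so the earlier compounds suggested that the position accepts change fairly easily. Tert-butoxycarbonyl shows that this acceptance has a limit: it gives a 9.4-fold higher number from compound 3 to compound 4 (0.98 log units; beyond the scatter), and the gaps from the two stronger compounds are wider still, at a 19-fold higher number from compound 2 to compound 4 (1.29 log units; beyond the scatter) and a 37-fold higher number from compound 1 to compound 4 (1.56 log units; beyond the scatter), leaving compound 4 the weakest inhibitor of the four. This single change brings in 7 heavy atoms in place of 1, along with a double bond outside the aromatic rings and 2 hydrogen-bond acceptors, and nothing available here indicates which of these features matters or why the inhibition falls.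

The compounds shown cannot separate the carbonyl from the rest of the new group, since an acetyl group on this nitrogen would keep the carbonyl with fewer carbons, while a butyl chain would add carbons without any carbonyl. As far as these compounds go, it also remains open whether a hydroxyethyl chain or an aminomethyl group would fit the trend set by hydroxymethyl in compound 1.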